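The source may hold more compounds than are shown below. What is called first, only, known or untested is meant among the compounds shown, and "the series" means these compounds.

In a functional assay on CaEs17 cells (Homo sapiens) for inhibition, read by MTT assay (a higher number here means a weaker inhibitor, a lower number a stronger inhibitor), compound 3 `C=C1C(=O)[C@@]23C(=O)OC[C@]4([C@@H](OC(C)=O)CCC(C)(C)[C@H]4C=O)[C@@H]2CC[C@H]1[C@H]3OC(C)=O` gives 2800 nM. Among the three measured compounds it stands apart from neither of the others: compound 1 `C=C1C(=O)[C@@]23C(=O)OC[C@]4([C@@H](OC(C)=O)CCC(C)(C)[C@H]4C=O)[C@@H]2CC[C@H]1[C@H]3OC(=O)CC` gives 2770 nM in this assay, and the step of a 1.0-fold higher number from compound 1 to compound 3 (0.00 log units; within the scatter) lies within the scatter, while compound 2 `C=C1C(=O)[C@@]23C(=O)OC[C@]4([C@@H](OC(C)=O)CCC(C)(C)[C@H]4C=O)[C@@H]2CC[C@H]1[C@H]3OC(=O)c1ccc(OC)cc1` gives 1960 nM, and the step of a 1.4-fold higher number from compound 2 to compound 3 (0.15 log units; within the scatter) also lies within the scatter. Compound 4 `C=C1C(=O)[C@@]23C(=O)OC[C@]4([C@@H](OC(C)=O)CCC(C)(C)[C@H]4C=O)[C@@H]2CC[C@H]1[C@H]3OC(=O)c1ccc(C(F)(F)F)cc1` differs from compound 3 at one place: 4-(trifluoromethyl)phenyl in place of methyl on a carbonyl carbon. For the measured compounds named here, two measured steps bear on this change. The step of a 1.4-fold higher number from compound 2 to compound 3 (0.15 log units; within the scatter) exchanges an aromatic group for methyl on the same carbonyl carbon without leaving the scatter, and the step of a 1.4-fold lower number from compound 1 to compound 2 (0.15 log units; within the scatter) exchanges an ethyl for an aromatic group there, again within the scatter. On this basis no step beyond the scatter is expected in this assay for compound 4, so that a 1.2-fold lower number from compound 3 to compound 4 (0.07 log units; within the scatter) is the expected move. Compound 4 is therefore estimated at 2400 nM, with a range from 1200 nM to 4800 nM.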

Compound 4, half-maximal inhibitory concentration: 9160 nM
Compound 4: middle estimate off by 3.8-fold (0.58 log units), on the low side; measured number outside the range, above it.
By their numbers in this assay, from the lowest: compounds 2, 1 and 3 (each within the scatter of the next); then compound 4.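

For the compounds shown here, until this result, no group on this carbonyl carbon had moved the number beyond the scatter in this assay; the 4-(trifluoromethyl)phenyl group does, with a 3.3-fold higher number from compound 3 to compound 4 (0.51 log units; beyond the scatter) and a 3.3-fold higher number from compound 1 to compound 4 (0.52 log units; beyond the scatter), so compound 4 is a weaker inhibitor than either. The aromatic ring alone does not account for the shift, since compound 2 also carries one, yet trifluoromethyl in place of methoxy on an aromatic carbon gives a 4.7-fold higher number from compound 2 to compound 4 (0.67 log units; beyond the scatter), which shows that the group on the ring matters at this position. Nothing measured here gives a reason for this shift.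

On these data alone, whether the weakening belongs to trifluoromethyl itself or would also appear with a nitrile, a chlorine or an amine on the aromatic ring remains open. Also open, as far as these compounds go, is how a longer chain or a cyclohexyl group on this carbonyl carbon would behave.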